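A few compounds are considered here, and "the series" means these few. Any claim that something is new, unique, unknown or untested is made for them only; others in the source may bear on it.

Measured so far:
compound 1, `C[C@H](NC(=O)CN(c1nc(Cl)nc2[nH]cnc12)C1CC1)C(=O)OCc1ccccc1`: 41.2%
compound 2, `O=C(CN(c1ncnc2c1ncn2C1CCCCO1)C1CC1)NCC(=O)OCc1ccccc1`: 55.7%

In a functional assay on the whole organism (Tail, strain ICR) with Mus musculus as the target, in the tail flick test, with a stated time of 30 min, at a dose of 25 umol/kg by the oral route (a lower number here means a weaker effect, a higher number a stronger effect of the compound at the dose given), compound 2 gives 55.7%, the higher of the two numbers. Its nearest neighbour, compound 1, gives 41.2%, a gap beyond the scatter. Going by the values given here, the two measured compounds differ in more than one place, so no single step between them is known. Compound 3, `O=C(CN(c1ncnc2c1ncn2C1CCCCO1)C1CC1)N[C@@H](CO)C(=O)OCc1ccccc1`, is still to be measured. It differs from compound 2 by hydroxymethyl in place of hydrogen on a saturated chain carbon bound to an amide-type nitrogen and a carbonyl carbon. Among the compounds with values here, no step of this kind has been measured, and compound 1 carries a different core, so it gives no direct guide. With nothing in the measured pair to point either way, the change is expected to give a step of modest size, within or only just beyond the scatter, with a slight lean toward a lower number. The expected step is a number 5.7 percentage points lower from compound 2 to compound 3 (within the scatter). Compound 3 is therefore estimated at 50% in this assay, within a range of 30% to 68%.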

Compound 3, a percentage reported as activity, at one dose (the size of the read-out at that dose, not a potency): 27.8%
The estimate for compound 3 lay 22.2 percentage points above the measured number; the whole stated range lies above it.
By their numbers in this assay, from the lowest: compound 3; then compound 1; then compound 2.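

In this assay, the saturated chain carbon bound to an amide-type nitrogen and a carbonyl carbon proves sensitive to substitution: hydroxymethyl in place of hydrogen gives a number 27.9 percentage points lower from compound 2 to compound 3 (beyond the scatter). Going by these compounds alone, this is the only single-place step so far, and it shows that, on the shared core of compound 2 and compound 3, this change lowers the effect at the dose given. Nothing measured here accounts for the size or direction of this step.

As far as these compounds go, whether the drop belongs to hydroxymethyl specifically or to any group on this carbon remains open: a methyl group there appears only in compound 1, whose core differs, so it offers no single-place comparison. Also open, from the compounds shown here alone, is how a longer chain or a carboxylic acid at this place would compare with hydrogen on the core of compound 2.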